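Heteroaryl swap on the amide-bearing ring: pyrazine to pyrimidine

The source may report more compounds than this note shows. Statements on the series, on what has been measured and on what is new or still open speak of the compounds shown alone.

Measured so far:
compound 1 `CC(C)(C)c1ccc(NC(=O)c2ccc(-c3ccccn3)cc2)cc1` gives 31 nM
compound 2 `CC(C)(C)c1ccc(NC(=O)c2ccc(-c3cccnc3)cc2)cc1` gives 1300 nM
compound 3 `CC(C)(C)c1ccc(NC(=O)c2ccc(-c3cnccn3)cc2)cc1` gives 1000 nM

All three numbers come from a functional assay on Dorsal root ganglion for antagonist activity at transient receptor potential cation channel subfamily V member 1 (Rattus norvegicus); on this read-out lower numbers stand for stronger inhibition and higher numbers for weaker inhibition. Compound 3 holds the second highest of the three values. Its nearest neighbour is compound 2: the step of a 1.3-fold lower number from compound 2 to compound 3 (0.11 log units; within the scatter) lies within the scatter, so the two cannot be ordered. Its furthest neighbour is compound 1: the step of a 32-fold higher number from compound 1 to compound 3 (1.51 log units; beyond the scatter) is large and well beyond the scatter, as is the parallel step a 42-fold higher number from compound 1 to compound 2 (1.62 log units; beyond the scatter).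

Compound 4 `CC(C)(C)c1ccc(NC(=O)c2ccc(-c3cncnc3)cc2)cc1` is the next member. Relative to compound 3 the change is pyrimidin-5-yl in place of pyrazin-2-yl on an aromatic carbon. Among the compounds with values here, no measured step involves pyrimidin-5-yl, so the bearing of the earlier data is indirect. Within the data shown here, the two large steps both concern the loss of pyridin-2-yl, which compound 3 has already given up; the only measured exchange between two heteroaryls that are not pyridin-2-yl is the step from compound 2 to compound 3, which stayed within the scatter. The expectation is therefore a step within the scatter, a 1.5-fold higher number from compound 3 to compound 4 (0.18 log units; within the scatter), with no direction that can be trusted. For compound 4 the estimated value in this assay is 1500 nM, with a range from 500 nM to 5000 nM.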

Compound 4, half-maximal inhibitory concentration: 10000 nM
For compound 4 the middle estimate is 6.7-fold (0.82 log units) below the measured one; the whole stated range lies below it.
By their numbers in this assay, from the lowest: compound 1; then compounds 3 and 2 (each within the scatter of the next); then compound 4.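

In this assay the choice of heteroaryl at this place, para to a large group, still counts once pyridin-2-yl has gone: pyrimidin-5-yl in place of pyrazin-2-yl gives a 10-fold higher number from compound 3 to compound 4 (1.00 log units; beyond the scatter) and in place of pyridin-3-yl gives a 7.7-fold higher number from compound 2 to compound 4 (0.89 log units; beyond the scatter), both modest but beyond the scatter. The earlier exchange between pyridin-3-yl and pyrazin-2-yl stayed within the scatter, so that level stretch does not extend to every heteroaryl, and pyrazin-2-yl and pyrimidin-5-yl show that rings with the same atoms and the same counted acceptors, joined differently, can still be told apart on this read-out. Measured against pyridin-2-yl, the exchange gives a 320-fold higher number from compound 1 to compound 4 (2.51 log units; beyond the scatter), the widest step in the set.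

Still open, on these data alone, is whether a pyrimidin-2-yl group at the same place, or a pyrimidin-5-yl ring carrying an amine or a methoxy group, would bring the number back toward that of compound 1. No measurement at hand accounts for the gap between pyrazin-2-yl and pyrimidin-5-yl or for the standing of pyridin-2-yl.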